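Swapping the aryl group on the sulfonyl of compound 2

This account rests on a few compounds, and the source may have more. Where it says the series, first, only, none or still open, it means among the compounds named here.

Compound 1 `N=C(NS(=O)(=O)c1ccccc1)N1CCN(c2cc3c(cc2F)c(=O)c(C(=O)O)cn3C2CC2)CC1` gives 71 nM in a functional assay on A549 cells (Homo sapiens) for antiproliferative activity, read by MTT assay, with a stated time of 72 h; a higher number here means a weaker inhibitor, a lower number a stronger inhibitor.
Compound 2 `CCn1cc(C(=O)O)c(=O)c2cc(F)c(N3CCN(C(=N)NS(=O)(=O)c4cccc(Cl)c4)CC3)cc21` gives 71 nM in this assay.
Compound 3 `N=C(NS(=O)(=O)c1cccc(Cl)c1)N1CCN(c2cc3c(cc2F)c(=O)c(C(=O)O)cn3C2CC2)CC1` gives 71 nM in this assay.

All three measured compounds share one core and sit level in this assay: compound 2 stands at the same value as compound 1 and compound 3, with no difference beyond the scatter.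

Compound 4 `CCn1cc(C(=O)O)c(=O)c2cc(F)c(N3CCN(C(=N)NS(=O)(=O)c4ccc(C)cc4)CC3)cc21` is not yet measured. It differs from compound 2 in one place: 4-methylphenyl in place of 3-chlorophenyl on a sulfonyl sulfur.

Two measured steps are known. The step of no change at the digits printed from compound 1 to compound 3 (within the scatter) changes the same phenyl on the sulfonyl sulfur and gives no change; the step of no change at the digits printed from compound 2 to compound 3 (within the scatter) touches a different part of the molecule and also gives no change. Going by the values given here, only the first bears on the change at hand, and it suggests that altering the substitution on this phenyl leaves the value unmoved.

For compound 4 the expected step is therefore no change at the digits printed from compound 2 to compound 4 (within the scatter), no change beyond the scatter. Compound 4 is estimated at 71 nM in this assay, with a range from 30 nM to 170 nM.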

Compound 4, half-maximal inhibitory concentration: 71 nM
Estimate against measurement, compound 4: no gap at the digits printed, within the range that was stated.
By their numbers in this assay, from the lowest: compounds 1, 2, 3 and 4 (each within the scatter of the next).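

In this assay, going by these compounds alone, 4-methylphenyl in place of 3-chlorophenyl on the sulfonyl sulfur gives no change at the digits printed from compound 2 to compound 4 (within the scatter), and this is the first step here that swaps one substituted phenyl for another. The earlier step at this ring only added a chloro to a bare phenyl on the cyclopropyl compounds, whereas this one removes the chloro and brings in a methyl under a different name position, on a compound carrying ethyl on the aromatic nitrogen. Nothing measured here explains why the value stays level across these groups.

The phenyl groups shown carry only hydrogen, chloro or methyl, so an amine, a carboxylic acid or a longer chain on this ring remains an open test. From the compounds shown here alone, whether 4-methylphenyl behaves the same alongside cyclopropyl is also open.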